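Permeability of a Shared Core with Varied Amide Groups

The source may hold more compounds than are shown below. What is called first, only, known or untested is meant among the compounds shown, and "the series" means these compounds.

Compound 1 `Cn1cncc1CN1CC(N(CC2CCN(C(=O)CNC(=O)OC(C)(C)C)CC2)S(=O)(=O)c2ccccn2)Cc2cc(C#N)ccc21` gives 0.5 10^-6 cm/s in an ADME assay on Caco-2 cells (Homo sapiens) for permeability, in the apical to basolateral direction; on this read-out lower numbers stand for lower permeability and higher numbers for higher permeability.
Compound 2 `CCC(=O)N1CCC(CN(C2Cc3cc(C#N)ccc3N(Cc3cncn3C)C2)S(=O)(=O)c2ccccn2)CC1` gives 0.5 10^-6 cm/s in this assay.
Compound 3 `Cn1cncc1CN1CC(N(CC2CCN(C(=O)NC(C)(C)C)CC2)S(=O)(=O)c2ccccn2)Cc2cc(C#N)ccc21` gives 0.6 10^-6 cm/s in this assay.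

All three share one core and differ only in the group on a carbonyl carbon. Compound 3 shows the highest of the three numbers, yet its gaps to compound 1 and to compound 2 both lie within the scatter. Compound 4 `CCCC(=O)N1CCC(CN(C2Cc3cc(C#N)ccc3N(Cc3cncn3C)C2)S(=O)(=O)c2ccccn2)CC1` differs from compound 3 by propyl in place of (tert-butyl)amino on a carbonyl carbon. The step that bears on this is a 1.2-fold higher number from compound 2 to compound 3 (0.08 log units; within the scatter), the reverse exchange of (tert-butyl)amino for ethyl on the same carbonyl carbon; a propyl is one carbon longer than an ethyl, so no step beyond the scatter is expected, and the estimated step is a 1.2-fold lower number from compound 3 to compound 4 (0.08 log units; within the scatter). Compound 4 is therefore expected to give 0.5 10^-6 cm/s, with a range from 0.25 10^-6 cm/s to 1 10^-6 cm/s.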

Compound 4, apparent permeability: 0.5 10^-6 cm/s
For compound 4 middle estimate and measured number coincide at the digits printed; the measured number falls inside the stated range.
By their numbers in this assay, from the lowest: compounds 1, 2, 4 and 3 (each within the scatter of the next).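

In this assay, replacing (tert-butyl)amino, a group with a hydrogen-bond donor, by propyl, a group without one, on this carbonyl carbon gives a 1.2-fold lower number from compound 3 to compound 4 (0.08 log units; within the scatter) at this position. Adding one methyl to the chain gives no change at the digits printed from compound 2 to compound 4 (within the scatter) and ethyl in place of (tert-butoxycarbonyl)amino gives no change at the digits printed from compound 1 to compound 4 (within the scatter) on the same chain. All four groups therefore sit within the scatter of one another, with or without that donor.

Nothing shown here explains this flat result. Going by these compounds, whether an amine, a carboxylic acid or a much longer chain at this place would move the number remains open.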